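Limits Only: An Inert Series Meets a Bulkier Aryl Group

The source may report more compounds than this note shows. Statements on the series, on what has been measured and on what is new or still open speak of the compounds shown alone.

Compound 1 `CC(C)N(Cc1cccc(OCCCCCC(=O)O)c1)C(=O)c1ccccc1`, compound 2 `CC(C)N(Cc1cccc(OCCCCCC(=O)O)c1)C(=O)c1ccc(-c2ccoc2)cc1` and compound 3 `CCOC(=O)CCCCCOc1cccc(CN(C(=O)c2ccc(-c3ccoc3)cc2)C(C)C)c1` share one core and differ in two places. In an ADME assay on Raji cells (Homo sapiens) for cytotoxicity, read by CellTiter-Glo and resazurin assay, with a stated time of 72 h (on this read-out lower numbers stand for an effect already at smaller amounts and higher numbers for an effect only at larger amounts of compound), compound 1 reaches only the limit of > 26000 nM. In this assay compound 2 likewise stops at the limit of > 26000 nM. Compound 3 also gives only the limit of > 26000 nM in this assay. Because every value sits at the same limit (the limit of > 26000 nM in this assay, at which 3 of the 3 values shown sit), neither measured step can be read: a step that the two limits leave unreadable from compound 1 to compound 2, and a step that the two limits leave unreadable from compound 2 to compound 3. Compound 3 thus stands exactly where the other two stand, at the limit, with no number to place it more finely.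

Compound 4 `CCOC(=O)CCCCCOc1cccc(CN(C(=O)c2ccc(-c3cccc(OC(F)(F)F)c3)cc2)C(C)C)c1` differs from compound 3 in one place: 3-(trifluoromethoxy)phenyl in place of furan-3-yl on an aromatic carbon. Among the compounds with values here, no measured step bears on this exchange; the two steps that exist are both unreadable and concern other parts of the molecule. The step in this assay is therefore expected to be a number no higher from compound 3 to compound 4 (the limit leaves the size open), nothing that rises above the scatter. Compound 4 is estimated at 26000 nM, with a range from 9000 nM to 80000 nM, and most probably this assay will again report only a limit.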

Compound 4, half-maximal effective concentration: > 26000 nM
Compound 4 ended at the assay's limit; the forecaster's own chance of this, stated with the estimate: 75%; the middle value lies on the limit itself.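

In this assay compound 4 gives > 26000 nM, which is a limit and not a number. No step between compound 3 and compound 4 can be read, since all the values sit at one limit: the limit of > 26000 nM in this assay, at which 4 of the 4 values shown sit.

The compounds shown leave open whether any member of this series has a measurable effect in this assay.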